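Phenyl for methylimidazolyl on the fused pyrimidine series

A few compounds are considered here, and "the series" means these few. Any claim that something is new, unique, unknown or untested is made for them only; others in the source may bear on it.

Of the compounds shown here, two have been measured in an assay for inhibition of 15-hydroxyprostaglandin dehydrogenase [NAD(+)] (Homo sapiens), read by fluorescence, with a stated time of 15 min, in the presence of a further agent that is not named here; on this read-out higher numbers stand for weaker inhibition and lower numbers for stronger inhibition. Compound 1 `CCCC[S+]([O-])c1cc2c(-c3ccccc3)nc(-c3ccccc3)nc2s1` gives 93 nM in this assay. Compound 2 `CCCC[S+]([O-])c1sc2nc(-c3nccn3C)nc(-c3ccccc3)c2c1N` gives 3.7 nM in this assay, the lowest of the two numbers, and the gap to compound 1 lies beyond the usual scatter. Compound 1 and compound 2 differ in more than one place, so the two values alone do not show which part of the difference carries the gap.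

Compound 3 `CCCC[S+]([O-])c1sc2nc(-c3ccccc3)nc(-c3ccccc3)c2c1N` has not been measured. Its change from compound 2 is phenyl in place of 1-methyl-1H-imidazol-2-yl on an aromatic carbon, between two ring nitrogen atoms. Compound 3 thereby shares the phenyl of compound 1 while keeping the amine of compound 2. No single-change step has been recorded for this series, so the expectation rests on the two numbers shown. A move upward from compound 2 toward the value of compound 1 is expected, likely beyond the scatter but not reaching compound 1, giving an estimated step of a 4.1-fold higher number from compound 2 to compound 3 (0.61 log units; beyond the scatter). For compound 3 the estimate in this assay is 15 nM, with a range of 4 nM to 60 nM.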

Compound 3, half-maximal inhibitory concentration: 4.9 nM
Compound 3: middle estimate off by 3.1-fold (0.49 log units), on the high side; the range from low to high includes it.
By their numbers in this assay, from the lowest: compounds 2 and 3 (each within the scatter of the next); then compound 1.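

In this assay, phenyl in place of 1-methyl-1H-imidazol-2-yl on the aromatic carbon between two ring nitrogen atoms gives a 1.3-fold higher number from compound 2 to compound 3 (0.12 log units; within the scatter), so this exchange of one aromatic ring for another does not separate compound 2 from compound 3, even though the hydrogen-bond acceptors counted on the group that leaves are absent from phenyl. Within the data shown here, compound 3 also turns the amino group into a single change for the first time: amino in place of hydrogen on an aromatic carbon gives a 19-fold lower number from compound 1 to compound 3 (1.28 log units; beyond the scatter), a large step that stands in clear contrast to the ring exchange. Nothing on hand gives a cause for either step.

Two aromatic rings at the position between two ring nitrogen atoms say nothing about how a non-aromatic group such as morpholine, or a carboxylic acid, would read in this assay. Going by these compounds, it also remains open whether the large step is specific to the primary amine, or whether a methylamino or hydroxyl group on the same carbon would give a similar value.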